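This account rests on a few compounds, and the source may have more. Where it says the series, first, only, none or still open, it means among the compounds named here.

Of the compounds shown here, three have been measured in an assay on isolated protein for inhibition of matrix metalloproteinase-9 (Homo sapiens); a higher number here means a weaker inhibitor, a lower number a stronger inhibitor. Compound 1, `O=C(OCc1ccccc1Br)c1cccc(=O)[nH]1`, gives 59000 nM. Compound 2, `O=C(OCc1cccc(Oc2ccccc2)c1)c1cccc(S)n1`, gives 75000 nM. Compound 3, `O=C(OCc1cccc(Oc2ccccc2)c1)c1cccc(=O)[nH]1`, gives > 150 nM, a value that is only a limit of this assay and not a number. Among the two numbers given, compound 2 sits alongside compound 1, the two within the scatter of repeated measurements, so neither can be called stronger or weaker than the other. Within the data shown here, the one single-point step, a step that the limit leaves unreadable from compound 2 to compound 3, cannot be sized, since the limit of > 150 nM in this assay, at which 1 of the 3 values shown sits, cuts off the reading for compound 3.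

Compound 4, `COc1cccc(COC(=O)c2cccc(S)n2)c1`, has not yet been measured. It differs from compound 2 by methyl in place of phenyl on an oxygen on an aromatic ring. Among the measured compounds shown here, no measured step changes this part of the structure: the step from compound 2 to compound 3 alters the group on the carbonyl carbon, and compound 1 differs from the others in more than one place. The measured steps therefore give no direct guidance, and the expectation for compound 4 in this assay is a step no larger than the scatter, in no preferred direction, as no change at the digits printed from compound 2 to compound 4 (within the scatter). On that basis compound 4 is estimated at 75000 nM, with a range from 30000 nM to 150000 nM.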

Compound 4, half-maximal inhibitory concentration: 93000 nM
For compound 4 the middle estimate is 1.2-fold (0.09 log units) below the measured one; the measured number falls inside the stated range.
By their numbers in this assay, from the lowest: compounds 1, 2 and 4 (each within the scatter of the next).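

In this assay, among these compounds, this is the first reading at the group on the oxygen: none of the earlier steps touched this part of the structure. Methoxy in place of phenoxy gives a 1.2-fold higher number from compound 2 to compound 4 (0.09 log units; within the scatter), so compounds 2 and 4 cannot be told apart, and on this core the outer phenyl ring can be replaced by a single methyl with no readable effect on the number. Nothing shown here offers a reason for this result.

On these data alone, compound 3 gives > 150 nM, which is a limit and not a number, so the steps to it cannot be read, and it remains open whether the same swap would also leave the number unmoved on the core of compound 3. Among the compounds shown here, also open is how this oxygen would tolerate a group of another kind, such as a longer chain like butyl or a chain ending in an amine or a carboxylic acid, since phenyl and methyl are the only two groups compared there so far.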